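The source may report more compounds than this note shows. Statements on the series, on what has been measured and on what is new or still open speak of the compounds shown alone.

Of the compounds shown here, two have been measured so far. Compound 1 `CS(=O)(=O)c1ccc(-c2nc(SCCOC(=O)/C=C/c3ccc(O)c(O)c3)nn2-c2ccccc2)cc1` gives 850 nM in an assay on cells (strain Sprague-Dawley) for inhibition of Polyunsaturated fatty acid 5-lipoxygenase (Rattus norvegicus), with a stated time of 30 min (a higher number here means a weaker inhibitor, a lower number a stronger inhibitor), and compound 2 `CS(=O)(=O)c1ccc(-c2nc(SCCCOC(=O)/C=C/c3ccc(O)c(O)c3)nn2-c2ccc(F)cc2)cc1` gives 710 nM in this assay; the two numbers sit within the scatter of each other, so compound 1 stands level with compound 2. Compound 3 `NS(=O)(=O)c1ccc(-c2nc(SCCOC(=O)/C=C/c3ccc(O)c(O)c3)nn2-c2ccccc2)cc1` has not yet been measured; it differs from compound 1 by amino in place of methyl on a sulfonyl sulfur. Among the measured compounds shown here, no measured pair shows this change, and nothing in the data points to a shift beyond the scatter in either direction. The step expected here, a 1.1-fold higher number from compound 1 to compound 3 (0.02 log units; within the scatter), is therefore small. Compound 3 is estimated at 900 nM, with a range from 400 nM to 2000 nM.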

Compound 3, half-maximal inhibitory concentration: 800 nM
For compound 3 the middle estimate is 1.1-fold (0.05 log units) above the measured one, within the range that was stated.
By their numbers in this assay, from the lowest: compounds 2, 3 and 1 (each within the scatter of the next).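

Replacing methyl with amino on a sulfonyl sulfur, which turns 4-(methylsulfonyl)phenyl into 4-sulfamoylphenyl, gives a 1.1-fold lower number from compound 1 to compound 3 (0.03 log units; within the scatter) in this assay. This first single-place step shows that the sulfur whose other neighbour is an aromatic carbon can carry either group, including the hydrogen-bond donor of amino, without a shift beyond the scatter. No measurement at hand accounts for this result.

From the compounds shown here alone, whether a dimethylamino or an ethyl group on the same sulfur would also leave the number within the scatter remains open. Going by these compounds, it is also open whether a carboxylic acid in place of the whole sulfonyl group would be tolerated.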